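Working notes: hydroxy in place of methylsulfonyl

The source may report more compounds than this note shows. Statements on the series, on what has been measured and on what is new or still open speak of the compounds shown alone.

compound 1 `CCCCOc1cccc(-c2[nH]c3cc(OC)ccc3c(=O)c2C(=O)OCC)c1` gives > 21500 nM (a limit)
compound 2 `CCOC(=O)c1c(-c2cccc(OC(F)(F)F)c2)[nH]c2cc(OC)ccc2c1=O` gives > 21500 nM (a limit)
compound 3 `CCOC(=O)c1c(-c2cccc(S(C)(=O)=O)c2)[nH]c2cc(OC)ccc2c1=O` gives > 21500 nM (a limit)

All three entries come from an ADME assay on HepG2 cells (Homo sapiens) for cytotoxicity, read by luminescence, with a stated time of 72 h (on this read-out lower numbers stand for an effect already at smaller amounts and higher numbers for an effect only at larger amounts of compound), and none of them is a number. Compound 3 gives > 21500 nM, which is a limit. The whole set so far sits on one line: the limit of > 21500 nM in this assay, at which 3 of the 3 values shown sit.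

The next compound, compound 4 `CCOC(=O)c1c(-c2cccc(O)c2)[nH]c2cc(OC)ccc2c1=O`, carries hydroxy in place of methylsulfonyl on an aromatic carbon, with the core of compound 3 otherwise unchanged: hydroxy in place of methylsulfonyl on an aromatic carbon.

Three measured steps swap the group on this same aromatic carbon: a step that the two limits leave unreadable from compound 1 to compound 3, a step that the two limits leave unreadable from compound 2 to compound 3 and a step that the two limits leave unreadable from compound 1 to compound 2. None of them has a readable size, so they give no direction for the new change. Hydroxy itself has not yet been seen in this series. The only anchor in this assay is compound 3 with > 21500 nM, again a limit, and on that basis no step beyond the usual scatter is expected. Another limit is the likeliest report for the new compound. The expected step is a number no higher from compound 3 to compound 4 (the limit leaves the size open). The estimate for compound 4 is 21500 nM, with an expected range from 11000 nM to 40000 nM.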

Compound 4, half-maximal effective concentration: > 21500 nM
Compound 4: a limit, no number; the forecaster's own chance of this, stated with the estimate: 85%; the middle value lies on the limit itself.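

Within the data shown here, compound 4 gives > 21500 nM in this assay, again a limit and not a number, so no step between compound 4 and compound 1, compound 2 or compound 3 can be read. The compounds shown leave open whether any of these groups on this aromatic carbon changes the read-out at all: the limit of > 21500 nM in this assay, at which 4 of the 4 values shown sit.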